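This account rests on a few compounds, and the source may have more. Where it says the series, first, only, none or still open, it means among the compounds named here.

Working notes on the shared core. For the measured compounds named here, in an assay on Sf9 cells for inhibition of protein deacetylase HDAC6 (Homo sapiens), read by fluorescence, with a stated time of 40 min, tested at 100 nM (on this read-out higher numbers stand for more inhibition at the one concentration tested (going by the name of the read-out) and lower numbers for less inhibition), compound 3 `O=C(NO)c1ccc(NCc2nc(-c3cccc(Cl)c3)nn2-c2ccccc2)cc1` gives 61.2%, the lowest of the three numbers so far; compound 1 `Cc1cccc(-c2nc(CNc3ccc(C(=O)NO)cc3)n(-c3ccccc3)n2)c1` gives 64.1%, a gap within the scatter, while compound 2 `O=C(NO)c1ccc(NCc2nc(-c3ccccc3Cl)nn2-c2ccccc2)cc1` gives 75%, the one clear separation, a number 13.8 percentage points lower from compound 2 to compound 3 (beyond the scatter). All three measured steps vary the same group on the aromatic carbon: a number 10.9 percentage points higher from compound 1 to compound 2 (beyond the scatter) and a number 2.9 percentage points lower from compound 1 to compound 3 (within the scatter), and none of them brings in thiophen-3-yl. Compound 4 `O=C(NO)c1ccc(NCc2nc(-c3ccsc3)nn2-c2ccccc2)cc1` is the next change at that place, (thiophen-3-yl in place of 3-chlorophenyl on an aromatic carbon). With only group-for-group swaps of modest size to go on, the step of a number 1.2 percentage points lower from compound 3 to compound 4 (within the scatter) is expected to stay near the scatter. Compound 4 is estimated at 60%, between 45% and 75%.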

Compound 4, a percentage reported as inhibition, at one concentration (the size of the read-out at that concentration, not a potency): 53.4%
Compound 4: middle estimate off by 6.6 percentage points, on the high side; low and high end bracket the measured number.
By their numbers in this assay, from the lowest: compounds 4, 3 and 1 (each within the scatter of the next, the first and the last beyond it); then compound 2.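

In this assay thiophen-3-yl, the first five-membered aromatic ring at this place, gives a number 21.6 percentage points lower from compound 2 to compound 4 (beyond the scatter) and also a number 10.7 percentage points lower from compound 1 to compound 4 (beyond the scatter) against the two groups compared there. The change from 3-chlorophenyl gives a number 7.8 percentage points lower from compound 3 to compound 4 (within the scatter) and so does not separate these two groups at this position. No measured evidence bears on the cause of these steps.

On these data alone, it remains open whether the number in this assay is higher, lower or level with a group without an aromatic ring, such as an amine or a carboxylic acid, on this carbon. As far as these compounds go, the effect of thiophen-2-yl at this place also remains open.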